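The compounds below may be only part of what the source reports. "The series", "measured", "known", "first", "only" and "open" are said of these compounds alone.

Measured compounds:
compound 1 `CCCCCCCCC(O)c1ccc2ccc(CC(O)CCCC(=O)O)nc2c1`: 900 nM
compound 2 `CCCCCCCCC(O)c1ccc2ccc(CCCCCC(=O)O)nc2c1`: 2800 nM

In an assay for inhibition of leukotriene B4 receptor 1 (Homo sapiens) (a lower number here means a stronger inhibitor, a higher number a weaker inhibitor), compound 2 gives 2800 nM, the higher of the two numbers recorded; compound 1 gives 900 nM. Among the measured compounds shown here, the single measured step, a 3.1-fold higher number from compound 1 to compound 2 (0.49 log units; beyond the scatter), concerns a hydroxy on the chain and not the acid-bearing end of the molecule. Compound 3 `CCCCCCCCC(O)c1ccc2ccc(CSc3cccc(C(=O)O)c3)nc2c1` is not yet measured; it differs from compound 2 by (3-carboxyphenyl)sulfanyl in place of 4-carboxybutyl on a saturated chain carbon bound to an aromatic carbon. For the measured compounds named here, no measured step bears on this exchange: the only step recorded alters a different part of compound 2, so its size says nothing about what the (3-carboxyphenyl)sulfanyl group does in place of the 4-carboxybutyl chain. The expectation therefore rests on the shared core alone and must be wide. Compound 3 is expected to give 1500 nM in this assay, with a range of 200 nM to 10000 nM. The expected step is a 1.9-fold lower number from compound 2 to compound 3 (0.27 log units; within the scatter), uncertain in direction.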

Compound 3, inhibition constant: 600 nM
For compound 3 the middle estimate is 2.5-fold (0.40 log units) above the measured one; low and high end bracket the measured number.
By their numbers in this assay, from the lowest: compounds 3 and 1 (each within the scatter of the next); then compound 2.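

In this assay, the acid-bearing end tolerates more than a saturated chain: (3-carboxyphenyl)sulfanyl in place of 4-carboxybutyl gives a 4.7-fold lower number from compound 2 to compound 3 (0.67 log units; beyond the scatter). The earlier step concerned only a hydroxy on the chain, whereas this one changes the group on the saturated chain carbon bound to an aromatic carbon and brings in a six-membered aromatic ring and a sulfur. Against the hydroxylated chain, the same group gives a 1.5-fold lower number from compound 1 to compound 3 (0.18 log units; within the scatter), so compound 3 matches compound 1 within the scatter while carrying no chain hydroxy.

Nothing available accounts for the size of either step. The sulfur and the aromatic ring enter together, so their shares remain unresolved, as does whether an ether oxygen in place of the sulfur, or a tetrazole in place of the carboxylic acid, would hold these numbers.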